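Swapping Isobutyl for Thiophen-2-yl at a Doubly Bonded Carbon

A few compounds are considered here, and "the series" means these few. Any claim that something is new, unique, unknown or untested is made for them only; others in the source may bear on it.

Of the compounds shown here, two that share one core have been measured. Compound 1 `Cc1cccc2nc(N/N=C\c3ccccc3)sc12` carries a phenyl group on a carbon with a double bond to nitrogen, and in a functional assay on cells (Erythrocyte, Homo sapiens) for inhibition, read by spectrophotometry and hemolysis, with a stated time of 10 min (a higher number here means a weaker inhibitor, a lower number a stronger inhibitor), compound 1 gives 80.1 ug/mL. Compound 2 `Cc1cccc2nc(N/N=C/CC(C)C)sc12` carries an isobutyl group there instead, and in this assay compound 2 gives 90.7 ug/mL. Compound 2 holds the highest of the two numbers, yet its gap to compound 1 lies within the scatter, so the two readings cannot be told apart. Compound 3 `Cc1cccc2nc(N/N=C/c3cccs3)sc12` is not yet measured. thiophen-2-yl in place of isobutyl on a carbon with a double bond to nitrogen An aromatic phenyl in compound 1 at 80.1 ug/mL and an aliphatic isobutyl in compound 2 at 90.7 ug/mL gave readings within the scatter of each other. The step expected from compound 2 to compound 3 is therefore a 1.1-fold lower number from compound 2 to compound 3 (0.04 log units; within the scatter), no change beyond the scatter. Compound 3 is estimated at 82 ug/mL, with a range from 40 ug/mL to 170 ug/mL.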

Compound 3, half-maximal inhibitory concentration: 28.7 ug/mL
Compound 3: the middle estimate sits 2.9-fold (0.46 log units) above what was measured; measured number below the stated range.
By their numbers in this assay, from the lowest: compound 3; then compounds 1 and 2 (each within the scatter of the next).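

In this assay, among the compounds shown here, the carbon with a double bond to nitrogen proves sensitive to what it carries: thiophen-2-yl in place of isobutyl gives a 3.2-fold lower number from compound 2 to compound 3 (0.50 log units; beyond the scatter) and this modest step is the first change here to exceed the scatter. An aromatic ring alone does not account for the lower number, since compound 1 carries phenyl and gives 80.1 ug/mL while compound 3 gives 28.7 ug/mL in the same assay. No measurement shown explains the step.

As far as these compounds go, whether the ring sulfur of thiophen-2-yl matters remains open, and furan-2-yl or pyridin-2-yl on the same carbon would help test it. Also open, from the compounds shown here alone, is whether a longer chain such as n-hexyl or an amine-bearing chain there would read like isobutyl or like thiophen-2-yl.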